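Benzyl ring substitution: from compound 3 to compound 4

This account rests on a few compounds, and the source may have more. Where it says the series, first, only, none or still open, it means among the compounds named here.

Measured so far in a functional assay on Raji cells (Homo sapiens) for antiproliferative activity, read by MTT assay, with a stated time of 72 h (on this read-out higher numbers stand for weaker inhibition and lower numbers for stronger inhibition), as follows
- compound 1 `CN(Cc1nc(C2CCN(Cc3ccccc3)CC2)no1)c1ncc(C(=O)NO)cn1` gives 27.6 nM
- compound 2 `Cc1cccc(CN2CCC(c3noc(CN(C)c4ncc(C(=O)NO)cn4)n3)CC2)c1` gives 47.3 nM
- compound 3 `CN(Cc1nc(C2CCN(Cc3ccccc3Cl)CC2)no1)c1ncc(C(=O)NO)cn1` gives 48.3 nM

Compound 3 cannot be separated from the other two, as shown by a 1.8-fold higher number from compound 1 to compound 3 (0.24 log units; within the scatter) and by a 1.0-fold higher number from compound 2 to compound 3 (0.01 log units; within the scatter) on these numbers. Compound 4 `CN(Cc1nc(C2CCN(Cc3ccc(F)cc3F)CC2)no1)c1ncc(C(=O)NO)cn1` is not yet measured and differs from compound 3 as follows 2,4-difluorophenyl in place of 2-chlorophenyl on a saturated chain carbon bound to an amine nitrogen in a ring with 2,4-difluorophenyl in place of 2-chlorophenyl. The closest evidence is a 1.7-fold higher number from compound 1 to compound 2 (0.23 log units; within the scatter) together with the two steps above, and all three stay within the scatter. No step beyond the scatter is therefore expected in this assay and the expected result is a 1.4-fold lower number from compound 3 to compound 4 (0.14 log units; within the scatter) without a firm direction. Compound 4 is estimated at 35 nM with an expected range from 15 nM to 80 nM in this series.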

Compound 4, half-maximal inhibitory concentration: 34.3 nM
Beside the measured number, compound 4's estimate is 1.0-fold (0.01 log units) above it; measured number inside the range.
By their numbers in this assay, from the lowest: compounds 1, 4, 2 and 3 (each within the scatter of the next).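

In this assay the place on a saturated chain carbon bound to an amine nitrogen in a ring also takes 2,4-difluorophenyl, with no separation from 2-chlorophenyl (a 1.4-fold lower number from compound 3 to compound 4 (0.15 log units; within the scatter)), 3-methylphenyl (a 1.4-fold lower number from compound 2 to compound 4 (0.14 log units; within the scatter)) or phenyl (a 1.2-fold higher number from compound 1 to compound 4 (0.09 log units; within the scatter)). Going by these compounds alone, exchanging one chlorine for two fluorine thus stays within the scatter, as the single methyl and chloro changes did. No accompanying measurement bears on these steps. Still open, going by these compounds, is whether a carboxylic acid or an amine on the benzyl ring, or a longer chain in place of the benzyl carbon, would give a step beyond the scatter.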